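The source may hold more compounds than are shown below. What is called first, only, known or untested is meant among the compounds shown, and "the series" means these compounds.

Working notes on the series. Of the compounds shown here, two have numbers so far, compound 1 `N#Cc1ccc(O[C@H]2CN(S(=O)(=O)c3ccc(Cl)cc3Cl)C[C@@]2(O)CN)cc1F` and compound 2 `N#Cc1ccc(O[C@H]2CN(S(=O)(=O)c3ccc(Cl)cc3Cl)C[C@]2(O)CO)cc1F`, both in an ADME assay on the whole organism (Rattus norvegicus, strain Sprague-Dawley) for pharmacokinetics, read by LC-MS; a lower number here means that a smaller share of the oral dose reaches the circulation, a higher number that a larger share of the oral dose reaches the circulation. Compound 1 gives 24% in this assay, which is the lowest of the two numbers held. Compound 2 gives 100% in this assay, a number that lies well beyond the usual scatter above that of compound 1. For the measured compounds named here, no single-place step connects these two compounds, so only the pair of values themselves is noted here.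

Compound 3 `N#Cc1ccc(O[C@H]2CN(S(=O)(=O)c3ccc(Cl)cn3)C[C@@]2(O)CN)cc1F` is the next compound to go into this assay. Compared with compound 1 it carries 5-chloropyridin-2-yl in place of 2,4-dichlorophenyl on a sulfonyl sulfur. Going by the values given here, no step of this kind has yet been measured in this assay, so nothing in the existing numbers points to a direction. The expected step from compound 1 to compound 3 in this assay is therefore a small one, a number 6 percentage points higher from compound 1 to compound 3 (within the scatter), not beyond the scatter. For compound 3 the estimated value in this assay is 30%, with an expected range from 10% to 60%.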

Compound 3, oral bioavailability: 26%
Estimate against measurement, compound 3: 4 percentage points above; the range from low to high includes it.
By their numbers in this assay, from the lowest: compounds 1 and 3 (each within the scatter of the next); then compound 2.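

On a sulfonyl sulfur whose other neighbour is the sulfonamide nitrogen in a ring, 5-chloropyridin-2-yl in place of 2,4-dichlorophenyl gives a number 2 percentage points higher from compound 1 to compound 3 (within the scatter) in this assay. For the compounds shown here, this is the only single-place step held, and it shows that, with the rest of compound 1 unchanged, a six-membered aromatic ring of carbon only can give way to one with 1 hetero atom without a step beyond the scatter. Nothing at hand accounts for this result.

Open, on these data alone, is whether this exchange gives a step of similar size on the background of compound 2, which carries a hydroxymethyl group where compound 1 carries an aminomethyl group. Also open, as far as these compounds go, is what a methyl or a trifluoromethyl group in place of the chlorine of 5-chloropyridin-2-yl would give in this assay.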